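Acylamino side-chain variation on the acylsulfonamide series

This account rests on a few compounds, and the source may have more. Where it says the series, first, only, none or still open, it means among the compounds named here.

Two compounds of the series have numbers in an assay on isolated protein for binding affinity to Apoptosis regulator Bcl-2 (Homo sapiens), read by fluorescence polarization; on this read-out higher numbers stand for weaker inhibition and lower numbers for stronger inhibition. Compound 1 `CC[C@H](C)[C@H](NC(C)=O)C(=O)Nc1ccc(C(=O)NS(=O)(=O)c2ccc(NCCSc3ccccc3)c([N+](=O)[O-])c2)cc1` gives 3380 nM in this assay. Compound 2 `CC(=O)N[C@@H](CC(C)C)C(=O)Nc1ccc(C(=O)NS(=O)(=O)c2ccc(NCCSc3ccccc3)c([N+](=O)[O-])c2)cc1` gives 3780 nM in this assay, the higher of the two numbers, though the difference a 1.1-fold higher number from compound 1 to compound 2 (0.05 log units; within the scatter) is within the scatter, so the two compounds cannot be ordered.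

Compound 3 `CSCC[C@H](NC(C)=O)C(=O)Nc1ccc(C(=O)NS(=O)(=O)c2ccc(NCCSc3ccccc3)c([N+](=O)[O-])c2)cc1` is the next member to be measured. It differs from compound 2 by (methylsulfanyl)methyl in place of isopropyl on a saturated chain carbon, two bonds along the chain from an amide-type nitrogen and a carbonyl carbon. Within the data shown here, the only measured step, from compound 1 to compound 2, is the exchange of one three-carbon side-chain end for another at the same place and left the number essentially unchanged, as a 1.1-fold higher number from compound 1 to compound 2 (0.05 log units; within the scatter) shows. The change to compound 3 is a comparable exchange of a group of the same atom count, so no step beyond the scatter is expected, and the estimated step is a 1.1-fold lower number from compound 2 to compound 3 (0.02 log units; within the scatter). Compound 3 is therefore expected to give about 3600 nM in this assay, with a range of 1500 nM to 8500 nM.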

Compound 3, inhibition constant: 3520 nM
Beside the measured number, compound 3's estimate is 1.0-fold (0.01 log units) above it; low and high end bracket the measured number.
By their numbers in this assay, from the lowest: compounds 1, 3 and 2 (each within the scatter of the next).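

Working notes: in this assay, the exchange of isopropyl for (methylsulfanyl)methyl, with sulfur entering the chain end and a hydrogen-bond acceptor gained, gives a 1.1-fold lower number from compound 2 to compound 3 (0.03 log units; within the scatter) and so leaves the number flat at this place. Read one bond further out, the comparison with the branched sec-butyl chain gives a 1.0-fold higher number from compound 1 to compound 3 (0.02 log units; within the scatter) as the step for 2-(methylsulfanyl)ethyl, so the three side chains cannot be ordered and a heteroatom in the chain has shown no effect beyond the scatter. No supporting data are available to explain this flat result.

Open, going by these compounds, is whether any group at this place moves the number beyond the scatter, for instance a terminal amine, a carboxylic acid, a phenyl ring or a longer chain. All three side chains shown are uncharged and without a ring, so the reach of this flatness remains undefined.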